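Replacing 1H-pyrazol-4-yl with piperidin-1-yl on the shared core

This account rests on a few compounds, and the source may have more. Where it says the series, first, only, none or still open, it means among the compounds named here.

Measured in a functional assay on MCF7 cells (Homo sapiens) for antiproliferative activity, read by CellTiter-Glo, with a stated time of 5 days; on this read-out lower numbers stand for stronger inhibition and higher numbers for weaker inhibition:

- compound 1 `CC/C(=C(/c1ccc(/C=C/C(=O)O)cc1)c1ccc(-c2cncs2)cc1)c1ccccc1` gives 31 nM
- compound 2 `CC/C(=C(/c1ccc(/C=C/C(=O)O)cc1)c1ccc(-c2cn[nH]c2)cc1)c1ccccc1` gives 40 nM

Within the data shown here, compound 2 stands level with compound 1, the only other measured compound, and the gap between them is a 1.3-fold higher number from compound 1 to compound 2 (0.11 log units; within the scatter). Compound 3 `CC/C(=C(/c1ccc(/C=C/C(=O)O)cc1)c1ccc(N2CCCCC2)cc1)c1ccccc1` has not yet been measured. In it, piperidin-1-yl takes the place of 1H-pyrazol-4-yl on an aromatic carbon, para to a large group (piperidin-1-yl in place of 1H-pyrazol-4-yl on an aromatic carbon). A five-membered aromatic ring thus gives way to a six-membered non-aromatic ring. Among the measured compounds shown here, the only measured step that bears on this is the exchange of 1,3-thiazol-5-yl for 1H-pyrazol-4-yl, and it was small, staying within the scatter. For the measured compounds named here, no measured compound carries a non-aromatic ring at this place, so that step offers only weak guidance. The estimate is anchored on compound 2 at 40 nM, and a modest move toward a higher number is expected, though no change remains possible. The expected step is a 1.8-fold higher number from compound 2 to compound 3 (0.24 log units; within the scatter). For compound 3 the estimated value is 70 nM, with an expected range from 20 nM to 250 nM.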

Compound 3, half-maximal inhibitory concentration: 450 nM
Estimate against measurement, compound 3: 6.4-fold (0.81 log units) below; the measured number lies above the stated range.
By their numbers in this assay, from the lowest: compounds 1 and 2 (each within the scatter of the next); then compound 3.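

In this assay, the exchange of 1,3-thiazol-5-yl for 1H-pyrazol-4-yl had suggested a forgiving position, with only a 1.3-fold higher number from compound 1 to compound 2 (0.11 log units; within the scatter), but the new result shows that this place on the aromatic carbon does respond to the group it carries: piperidin-1-yl gives an 11-fold higher number from compound 2 to compound 3 (1.05 log units; beyond the scatter), and measured against the thiazole it gives a 15-fold higher number from compound 1 to compound 3 (1.16 log units; beyond the scatter). The two five-membered aromatic rings stay within the scatter of each other, while the six-membered non-aromatic ring of compound 3 stands clearly apart from both, so the tolerance seen earlier does not extend to every ring at this position. Nothing measured here explains the loss, and the size of the step remains an observation without a known cause.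

This single change alters ring size, aromatic character and the hydrogen-bond donor count at once, so the compounds shown cannot say which of these differences carries the step. A phenyl ring or a pyrrolidin-1-yl ring at this place would begin to separate ring size from aromatic character, and a 1-methylpyrazol-4-yl group would bear on the role of the pyrazole hydrogen.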